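A few compounds are considered here, and "the series" means these few. Any claim that something is new, unique, unknown or untested is made for them only; others in the source may bear on it.

Compound 3 `CN1CCN(CCCOc2cccc3nc(Nc4cc(Cl)cc(Cl)c4)ccc23)CC1` gives 1680 nM in a functional assay on cells (Panel colon (Carcinoma cell lines), Homo sapiens) for inhibition, read by sulforhodamine B assay, with a stated time of 48 h (on this read-out lower numbers stand for stronger inhibition of growth and higher numbers for weaker inhibition of growth), the lowest of the three numbers measured. Compound 2 `CN1CCN(CCCOc2cccc3nc(Nc4ccc(F)c(F)c4)ccc23)CC1` gives 2110 nM, and the gap a 1.3-fold lower number from compound 2 to compound 3 (0.10 log units; within the scatter) stays within the scatter, so these two cannot be ranked against each other. Compound 1 `CC(C)c1ccc(Nc2ccc3c(OCCCN4CCN(C)CC4)cccc3n2)cc1` gives 4850 nM, and both a 2.9-fold lower number from compound 1 to compound 3 (0.46 log units; beyond the scatter) and a 2.3-fold lower number from compound 1 to compound 2 (0.36 log units; beyond the scatter) are modest moves beyond the scatter. Compound 4 `CN1CCN(CCCOc2cccc3nc(Nc4ccc(Cl)c(C(F)(F)F)c4)ccc23)CC1` has not yet been measured. Its change from compound 3 is 4-chloro-3-(trifluoromethyl)phenyl in place of 3,5-dichlorophenyl on a nitrogen on an aromatic ring. The two halogenated groups already measured on this nitrogen gave similar numbers, so a further halogenated group is expected to stay close to compound 3. The estimated step of a 1.1-fold lower number from compound 3 to compound 4 (0.05 log units; within the scatter) would lie within the scatter. Compound 4 is therefore expected near 1500 nM, between 700 nM and 3200 nM.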

Compound 4, concentration for 50% growth inhibition: 1580 nM
Compound 4: middle estimate off by 1.1-fold (0.02 log units), on the low side; the measured number falls inside the stated range.
By their numbers in this assay, from the lowest: compounds 4, 3 and 2 (each within the scatter of the next); then compound 1.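

At the nitrogen on an aromatic ring, a larger group of 11 heavy atoms instead of 8 still gives a number in this assay that cannot be told apart from its halogenated neighbours: a 1.1-fold lower number from compound 3 to compound 4 (0.03 log units; within the scatter) and a 1.3-fold lower number from compound 2 to compound 4 (0.13 log units; within the scatter) both stay within the scatter. Only the comparison with 4-isopropylphenyl stands out, with a 3.1-fold lower number from compound 1 to compound 4 (0.49 log units; beyond the scatter). This step is of the same modest size as the steps from compound 1 to compound 2 and to compound 3. Nothing available explains this grouping. From the compounds shown here alone, whether a plain phenyl, or a phenyl carrying an amine or a carboxylic acid, would match the halogenated groups or compound 1 stays open.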